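Smaller groups on the carbon bound to aromatic nitrogen

This account rests on a few compounds, and the source may have more. Where it says the series, first, only, none or still open, it means among the compounds named here.

Measured so far:
Compound 1, `O=C(C1CC1)N1CCN(Cc2nc3ccccc3n2Cc2ccccc2C(F)(F)F)CC1`: 56.3%
Compound 2, `CC(C)Cn1c(CN2CCN(C(=O)C3CC3)CC2)nc2ccccc21`: 13.1%
Compound 3, `Cc1ccccc1Cn1c(CN2CCN(C(=O)C3CC3)CC2)nc2ccccc21`: 29.1%

In an assay on isolated protein for inhibition of aldehyde dehydrogenase 1A1 (Homo sapiens), read by spectrophotometry, tested at 10 uM (a higher number here means more inhibition at the concentration tested (going by the name of the read-out), a lower number less inhibition), compound 3 stands second highest of the three, above compound 2 and below compound 1. The two steps that reach it are both beyond the scatter: a number 27.2 percentage points lower from compound 1 to compound 3 (beyond the scatter) and a number 16 percentage points higher from compound 2 to compound 3 (beyond the scatter). The largest step in the set, a number 43.2 percentage points lower from compound 1 to compound 2 (beyond the scatter), also trades an aryl group for a small branched alkyl group at the same place.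

Compound 4, `CC(C)=CCn1c(CN2CCN(C(=O)C3CC3)CC2)nc2ccccc21`, differs from compound 3 by 2-methylprop-1-en-1-yl in place of 2-methylphenyl on a saturated chain carbon bound to an aromatic nitrogen. The group entering is a short, unbranched-ring-free alkenyl group of four carbon atoms, much closer in kind to the isopropyl of compound 2 than to the 2-methylphenyl of compound 3. The step from compound 2 to compound 3 shows that the six-membered aromatic ring adds inhibition; taking it away again is expected to cost roughly that amount, so for compound 4 a drop of about a number 11.1 percentage points lower from compound 3 to compound 4 (beyond the scatter) is expected. Compound 4 is estimated at 18%, between 5% and 35%.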

Compound 4, a percentage reported as inhibition, at one concentration (the size of the read-out at that concentration, not a potency): 74.3%
For compound 4 the middle estimate is 56.3 percentage points below the measured one, and the stated range ends below it.
By their numbers in this assay, from the lowest: compound 2; then compound 3; then compound 1; then compound 4.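

In this assay the ring-free 2-methylprop-1-en-1-yl gives the highest number of the four, with a number 45.2 percentage points higher from compound 3 to compound 4 (beyond the scatter) and a number 18 percentage points higher from compound 1 to compound 4 (beyond the scatter), so an aromatic ring is not required for inhibition on this saturated chain carbon bound to an aromatic nitrogen. Groups without a ring do not behave alike at this place either, as a number 61.2 percentage points higher from compound 2 to compound 4 (beyond the scatter) separates two such groups. No measurement at hand accounts for these steps.

The compounds shown leave open whether the double bond is needed for the higher number, which the saturated 3-methylbutyl group at the same place could test. Also open, going by these compounds, is whether a chain ending in an amine or a carboxylic acid would keep the inhibition seen with compound 4.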